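The compounds below may be only part of what the source reports. "The series", "measured", "known", "first", "only" and "open" are said of these compounds alone.

Values so far in an ADME assay on MT4 cells (Homo sapiens) for cytotoxicity, read by MTT assay, with a stated time of 4 days (a lower number here means that less compound is tolerated, a higher number that more compound is tolerated), are
- compound 1 `C/C(=N\NC(=O)COc1cccc2ccccc12)c1ccc(C#N)cc1Br` gives 12.1 ug/mL
- compound 2 `O=C(COc1cccc2ccccc12)N/N=C/c1ccccc1O` gives 5.19 ug/mL
- compound 3 `O=C(COc1cccc2ccccc12)N/N=C/c1ccccc1` gives >= 96.6 ug/mL (a limit)

Compound 1 holds the higher of the two exact numbers, and compound 2 lies lower, beyond the scatter. Compound 3 gives only a limit. Moving to compound 4 `C/C(=N\NC(=O)COc1cccc2ccccc12)c1ccc(O)cc1` puts 4-hydroxyphenyl in place of 2-bromo-4-cyanophenyl on a carbon with a double bond to nitrogen. Among the measured compounds shown here, one measured step bears on this: hydrogen in place of hydroxy on an aromatic carbon gave a large change (an at least 18-fold higher number from compound 2 to compound 3 (1.26 log units; beyond the scatter)). Compound 4 carries a hydroxy as compound 2 does, while compound 1 has none and still gives 12.1 ug/mL as its number, so that step should transfer only in part. The expected step in this assay is a modest rise (a 2.3-fold higher number from compound 1 to compound 4 (0.36 log units; beyond the scatter)). Compound 4 is estimated at 28 ug/mL with an expected range from 7 ug/mL to 96 ug/mL overall.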

Compound 4, half-maximal cytotoxic concentration: 68.8 ug/mL
Compound 4: middle estimate off by 2.5-fold (0.39 log units), on the low side; low and high end bracket the measured number.
By their numbers in this assay, from the lowest: compound 2; then compound 1; then compound 4. At a limit, above all of these: compound 3.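

In this assay, putting 4-hydroxyphenyl in place of 2-bromo-4-cyanophenyl on this carbon gives a 5.7-fold higher number from compound 1 to compound 4 (0.75 log units; beyond the scatter), so the group held here affects how much compound is tolerated. A group carrying a hydroxy enters and the number still rises, so a hydroxy on an aromatic carbon does not lower the number in every setting. Among the compounds shown here, nothing measured so far explains this rise. Going by these compounds, the step changes the bromine, the nitrile and the hydroxy together, so the share of each remains unknown. Also open, on these data alone, is what an amine in place of that hydroxy would give.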